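The source may hold more compounds than are shown below. What is called first, only, known or untested is meant among the compounds shown, and "the series" means these compounds.

Compound 1 `O=C(NCCCCc1ccccc1)c1cccc(C2SCC(=O)N2c2cccc(-c3c[nH]nn3)c2)c1` in a functional assay on HOS-TE85 cells (Homo sapiens) for inhibition, read by CCK-8 assay, with a stated time of 72 h (on this read-out lower numbers stand for stronger inhibition and higher numbers for weaker inhibition), gives 110 nM, the highest of the two numbers shown. Compound 2 `COc1ccccc1N1C(=O)CSC1c1cccc(C(=O)NCCCCc2ccc(Cl)cc2)c1` gives 78.6 nM, which sits within the scatter of compound 1. Compound 3 `COc1ccccc1N1C(=O)CSC1c1cccc(C(=O)NCCCCn2cncn2)c1` reaches only the limit of this assay, > 1000 nM. Going by the values given here, the one measured step, an at least 12-fold higher number from compound 2 to compound 3 (1.10 log units; beyond the scatter), changes the end of the chain and shows that a flat ring with several nitrogens at the chain end can sharply weaken inhibition (the limit of > 1000 nM in this assay, at which 1 of the 3 values shown sits). Compound 4 `O=C(NCCCCc1ccccc1)c1cccc(C2SCC(=O)N2c2cnccn2)c1` differs from compound 1 by a group of 6 heavy atoms (4 carbon, 2 nitrogen; one six-membered aromatic ring with 2 hetero atoms) in place of a group of 11 heavy atoms (8 carbon, 3 nitrogen; one five-membered aromatic ring with 3 hetero atoms, one six-membered aromatic ring of carbon only), on an amide-type nitrogen in a ring. Among the compounds with values here, no measured step touches that ring nitrogen, so the expectation is uncertain; the step of a 2.4-fold higher number from compound 1 to compound 4 (0.37 log units; beyond the scatter) is expected to be a moderate weakening. Compound 4 is estimated at 260 nM, within 80 nM to 900 nM.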

Compound 4, half-maximal inhibitory concentration: > 1000 nM
Compound 4: a limit, no number; the forecaster's own chance of this, stated with the estimate: 15%; at least 3.8-fold (0.58 log units) between middle value and limit.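

Putting pyrazin-2-yl in place of the larger group on the amide-type nitrogen in the ring gives an at least 9.0-fold higher number from compound 1 to compound 4 (0.95 log units; beyond the scatter). This shows that inhibition in this assay depends on this ring position as well as on the chain end, the only place changed by the earlier step. The value of compound 4 is a limit, not a number, and compound 3 shares it: the limit of > 1000 nM in this assay, at which 2 of the 4 values shown sit.

Since the whole group changes at once, the step cannot show which part of it matters. Also open, on these data alone, is how a pyridin-2-yl group or a phenyl ring carrying an amine would fare at this position.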